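A few compounds are considered here, and "the series" means these few. Any claim that something is new, unique, unknown or untested is made for them only; others in the source may bear on it.

In a functional assay on HeLa cells (Homo sapiens) for cytotoxicity, read by MTT assay (a higher number here means a weaker inhibitor, a lower number a stronger inhibitor), compound 1 `CC(C)[C@H](NC(=S)Nc1ccccc1)c1nc2ccccc2[nH]1` gives 11100 nM, compound 2 `CC(C)C[C@H](NC(=S)Nc1ccccc1)c1nc2ccccc2[nH]1` gives 29100 nM and compound 3 `C[C@@H](NC(=S)Nc1ccccc1)c1nc2ccccc2[nH]1` gives 12400 nM. Compound 3 stands second highest of the three numbers, within the scatter of compound 1 and beyond it from compound 2. Going by the values given here, the only single-point step seen so far is a 2.6-fold higher number from compound 1 to compound 2 (0.42 log units; beyond the scatter), a change of the chain at the stereocentre rather than of its configuration. Compound 4 `C[C@H](NC(=S)Nc1ccccc1)c1nc2ccccc2[nH]1` differs from compound 3 as follows: the two compounds have the same atoms and bonds and differ only in configuration as drawn: 1 of 1 stereo elements differ; a stereocentre at a saturated chain carbon is drawn R in compound 3 and S in compound 4. Among the compounds with values here, no measured pair bears on a change of configuration alone, so nothing supports a step in this assay beyond the scatter in either direction. Compound 4 is therefore expected to give about 12400 nM, in the range 4000 nM to 40000 nM. The expected step is no change at the digits printed from compound 3 to compound 4 (within the scatter).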

Compound 4, half-maximal inhibitory concentration: "not active" (no number reported)
No number was reported for compound 4; no gap can be computed for the estimate.
By their numbers in this assay, from the lowest: compounds 1 and 3 (each within the scatter of the next); then compound 2.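

In this assay, going by these compounds alone, compound 4 is reported only as not active, without a number, so no step from compound 3 can be read. Within the data shown here, still open is how far the number moves with the single difference in this pair: the fact that compounds 3 and 4 differ only in the configuration as drawn.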